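A few compounds are considered here, and "the series" means these few. Any claim that something is new, unique, unknown or untested is made for them only; others in the source may bear on it.

Notes on the series. Among the compounds with values here, compound 1 `CCC(C)(C)Cc1c[nH]c(CCc2ccc(-c3cnccn3)cc2)n1` carries pyrazin-2-yl on the shared core; in an in vitro assay on CHO cells for displacement of a labelled ligand from Bombesin receptor subtype-3 (Homo sapiens), read by scintillation counting, with a stated time of 2 h (on this read-out higher numbers stand for weaker inhibition and lower numbers for stronger inhibition), compound 1 gives 51 nM, the highest of the three numbers measured so far. Compound 2 `CCC(C)(C)Cc1c[nH]c(CCc2ccc(-c3ccccc3C(=O)O)cc2)n1`, with 2-carboxyphenyl in that position, gives 11 nM in this assay, and compound 3 `CCC(C)(C)Cc1c[nH]c(CCc2ccc(-c3cccnc3)cc2)n1`, with pyridin-3-yl, gives 7.5 nM. Both replacements of pyrazin-2-yl bring the number down: a 4.6-fold lower number from compound 1 to compound 2 (0.67 log units; beyond the scatter) and a 6.8-fold lower number from compound 1 to compound 3 (0.83 log units; beyond the scatter). Between those two replacements the gap is small, a 1.5-fold lower number from compound 2 to compound 3 (0.17 log units; within the scatter).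

Compound 4 `CCC(C)(C)Cc1c[nH]c(CCc2ccc(-c3ccns3)cc2)n1` is not yet measured. Relative to compound 1 the change is 1,2-thiazol-5-yl in place of pyrazin-2-yl on an aromatic carbon. The two measured steps that bear on it, from compound 1 to compound 2 and from compound 1 to compound 3, both swap pyrazin-2-yl for another aromatic ring on an aromatic carbon and both give modest drops; neither involves a five-membered aromatic ring, so the size of the step for 1,2-thiazol-5-yl is less certain. Within the data shown here, nothing among the measured compounds points to a higher number. On this basis a modest drop in this assay is expected, a 3.4-fold lower number from compound 1 to compound 4 (0.53 log units; beyond the scatter). Compound 4 is therefore estimated at 15 nM in this assay, with a range from 5 nM to 45 nM.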

Compound 4, half-maximal inhibitory concentration: 11 nM
Beside the measured number, compound 4's estimate is 1.4-fold (0.13 log units) above it; the measured number falls inside the stated range.
By their numbers in this assay, from the lowest: compounds 3, 2 and 4 (each within the scatter of the next); then compound 1.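

Placing a five-membered aromatic ring on this aromatic carbon, para to a large group, still lowers the number relative to pyrazin-2-yl in this assay (a 4.6-fold lower number from compound 1 to compound 4 (0.67 log units; beyond the scatter)), so a six-membered ring is not required here for a step of this size. 1,2-Thiazol-5-yl also cannot be separated from the other two replacements (a 1.5-fold higher number from compound 3 to compound 4 (0.17 log units; within the scatter); no change at the digits printed from compound 2 to compound 4 (within the scatter)), which leaves pyrazin-2-yl as the only one of the four groups standing apart, while ring size and the sulfur atom show no visible penalty in this small set. No measurement shown gives a reason for the higher number with pyrazin-2-yl or for the closeness of the other three groups.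

On these data alone, all four groups at this position are aromatic rings, so it remains open whether a saturated ring such as morpholine, a primary amine or a short alkyl chain would keep the number in this range. As far as these compounds go, it also remains open whether the higher number belongs to pyrazin-2-yl alone or extends to a pyrimidin-5-yl ring, and whether a thiophen-2-yl ring, with sulfur but no ring nitrogen, would match 1,2-thiazol-5-yl.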